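This account rests on a few compounds, and the source may have more. Where it says the series, first, only, none or still open, it means among the compounds named here.

Measured compounds:
compound 1 `CC(C)=CCC/C(C)=C/CCC1=C[C@H](c2ccccc2[N+](=O)[O-])OC1=O` — 18900 nM
compound 2 `CC(C)=CCC/C(C)=C/CCC1=C[C@H](c2ccc(C(C)(C)C)cc2)OC1=O` — 5820 nM
compound 3 `CCc1ccc([C@H]2C=C(CC/C=C(\C)CCC=C(C)C)C(=O)O2)cc1` — 14200 nM

Of the compounds shown here, three sharing one core have been measured in an assay on microsomes from liver for inhibition of 3-hydroxy-3-methylglutaryl-coenzyme A reductase (Sus scrofa), read by colorimetric assay; on this read-out lower numbers stand for stronger inhibition and higher numbers for weaker inhibition. Compound 2 gives 5820 nM, the lowest number of the three; compound 3 gives 14200 nM, and compound 1, which also carries a nitro group on its aromatic ring, gives 18900 nM. Compound 4 `CC(C)=CCC/C(C)=C/CCC1=C[C@H](c2ccc([N+](=O)[O-])cc2)OC1=O` has not yet been measured. It differs from compound 2 in one place: nitro in place of tert-butyl on an aromatic carbon. Among the measured compounds shown here, only one measured step bears directly on this change: a 2.4-fold higher number from compound 2 to compound 3 (0.39 log units; beyond the scatter), where a smaller alkyl group took the place of the tert-butyl group and the number rose beyond the scatter. For the measured compounds named here, the two values of compound 1 and compound 2 show that a nitro-bearing analogue sits at a clearly higher number, though no single-point step links those two. In this assay a rise is therefore expected for compound 4, roughly a 2.9-fold higher number from compound 2 to compound 4 (0.47 log units; beyond the scatter). The estimated value for compound 4 is 17000 nM, with a range from 7000 nM to 40000 nM.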

Compound 4, half-maximal inhibitory concentration: 7430 nM
Compound 4: middle estimate off by 2.3-fold (0.36 log units), on the high side; the measured number falls inside the stated range.
By their numbers in this assay, from the lowest: compounds 2, 4, 3 and 1 (each within the scatter of the next, the first and the last beyond it).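

In this assay, nitro in place of tert-butyl on this aromatic carbon, para to a large group, leaves the number within the scatter (a 1.3-fold higher number from compound 2 to compound 4 (0.11 log units; within the scatter)). The step to ethyl had been the only one at this position and lay beyond the scatter (a 2.4-fold higher number from compound 2 to compound 3 (0.39 log units; beyond the scatter)), so it now stands against a replacement that does not separate from tert-butyl, even though nitro brings hydrogen-bond acceptors that tert-butyl lacks; nitro does not separate from ethyl either (a 1.9-fold lower number from compound 3 to compound 4 (0.28 log units; within the scatter)). Nothing at hand accounts for this result.

As far as these compounds go, whether an amine, a carboxylic acid or a methoxy group at this place would also stay within the scatter of tert-butyl remains open. So does whether a longer alkyl chain would behave like ethyl or like tert-butyl.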